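Series notes: from compound 3 to compound 4

The source may hold more compounds than are shown below. What is called first, only, known or untested is meant among the compounds shown, and "the series" means these compounds.

Measured in a functional assay on DU-145 cells (Homo sapiens) for inhibition, read by sulforhodamine B assay, with a stated time of 48 h, tested at 10 uM; a lower number here means a stronger effect, a higher number a weaker effect of the compound at the concentration tested:
- compound 1 `COc1cc(Cl)cc(-c2nn(-c3cccc(NC(=O)c4ccc(Cl)c(Cl)c4)c3)cc2-c2ccncc2)c1`: 88.5%
- compound 2 `O=C(Nc1cccc(-n2cc(-c3ccncc3)c(-c3cc(O)cc(Cl)c3)n2)c1)Nc1ccc(Cl)c(C(F)(F)F)c1`: 18.7%
- compound 3 `COc1cc(Cl)cc(-c2nn(-c3cccc(NC(=O)Nc4ccc(Cl)c(C(F)(F)F)c4)c3)cc2-c2ccncc2)c1`: 15.2%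

Compound 3 shows the lowest of the three numbers; compound 2 is nearest, within the scatter, and compound 1 is furthest, beyond it. Compound 4 `COc1cc(Cl)cc(-c2nn(-c3cccc(NC(=O)Nc4cccc(C(F)(F)F)c4)c3)cc2-c2ccncc2)c1` differs from compound 3 by hydrogen in place of chloro on an aromatic carbon. Two steps are known: a number 73.3 percentage points lower from compound 1 to compound 3 (beyond the scatter), and a number 3.5 percentage points lower from compound 2 to compound 3 (within the scatter). Among the measured compounds shown here, neither removes a chloro from that ring, so no measured step bears directly on this change. Some loss of effect is expected; the estimated step is a number 12.8 percentage points higher from compound 3 to compound 4 (beyond the scatter). For compound 4 the expected value in this assay is 28%, with a range from 12% to 55%.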

Compound 4, a percentage reported as activity, at one concentration (the size of the read-out at that concentration, not a potency): 15.9%
Compound 4: middle estimate off by 12.1 percentage points, on the high side; low and high end bracket the measured number.
By their numbers in this assay, from the lowest: compounds 3, 4 and 2 (each within the scatter of the next); then compound 1.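

In this assay, the chloro ortho to the trifluoromethyl group can give way to hydrogen with no change beyond the scatter, as a number 0.7 percentage points higher from compound 3 to compound 4 (within the scatter) shows. Without that chloro, the (3-(trifluoromethyl)phenyl)amino group still retains the large difference from 3,4-dichlorophenyl on the carbonyl carbon, with a number 72.6 percentage points lower from compound 1 to compound 4 (beyond the scatter). No measurement shown here explains either step.

From the compounds shown here alone, whether the trifluoromethyl group alone carries this effect remains open, as does how an amine or a nitrile would behave at the former chloro position. A single concentration also cannot separate the potencies of compound 3 and compound 4.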